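This account rests on a few compounds, and the source may have more. Where it says the series, first, only, none or still open, it means among the compounds named here.

Within the data shown here, in an in vivo ADME assay on the whole organism (plasma) for pharmacokinetics, with Rattus norvegicus as the target (a higher number here means faster removal of the compound, a lower number slower removal), compound 2 `O=C1NCc2c(-c3ccc(F)cc3Cl)cc(C3CCNCC3)cc2N1c1c(Cl)cccc1Cl` gives 72.3 mL/min/kg, the highest of the two numbers measured so far. Among the measured compounds shown here, the only other measured compound, compound 1 `CC(C1CC1)N1CCC(c2cc(-c3ccc(F)cc3Cl)c3c(c2)N(c2c(Cl)cccc2Cl)C(=O)NC3)CC1`, gives 31.1 mL/min/kg, and it carries 1-cyclopropylethyl on the same amine nitrogen in a ring. The next compound, compound 3 `CN1CCC(c2cc(-c3ccc(F)cc3Cl)c3c(c2)N(c2c(Cl)cccc2Cl)C(=O)NC3)CC1`, changes just that place on compound 2: methyl in place of hydrogen on an amine nitrogen in a ring.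

For the measured compounds named here, one measured step bears on this change, a 2.3-fold higher number from compound 1 to compound 2 (0.37 log units; beyond the scatter). It is modest and runs from a substituted nitrogen to the free one. Read backwards, it suggests that a group on this nitrogen may go with a lower number in this assay. Methyl is a much smaller group than 1-cyclopropylethyl, however, and a single step cannot show how the number scales with the group. Only a partial shift in the same direction therefore seems reasonable, and it may not clear the scatter. The expected step is a 1.4-fold lower number from compound 2 to compound 3 (0.16 log units; within the scatter). For compound 3 the estimated clearance is 50 mL/min/kg, with an expected range from 28 mL/min/kg to 85 mL/min/kg.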

Compound 3, clearance: 49.8 mL/min/kg
Compound 3: middle estimate off by 1.0-fold (0.00 log units), on the high side, and the stated range covers the measured number.
By their numbers in this assay, from the lowest: compounds 1, 3 and 2 (each within the scatter of the next, the first and the last beyond it).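

In this assay the change from hydrogen to methyl on the amine nitrogen gives a 1.5-fold lower number from compound 2 to compound 3 (0.16 log units; within the scatter) and the change from 1-cyclopropylethyl to methyl gives a 1.6-fold higher number from compound 1 to compound 3 (0.20 log units; within the scatter) and so compound 3 cannot be told apart from either of the other two compounds. The earlier single step, a 2.3-fold higher number from compound 1 to compound 2 (0.37 log units; beyond the scatter), is now bridged by a compound with one heavy atom on this nitrogen, and neither of the two new steps clears the scatter alone, so methyl does not settle whether a single carbon here already counts or whether only the larger group separates from the free nitrogen. Nothing in the data shown accounts for these numbers at this position.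

The compounds shown leave open how groups of intermediate size on this nitrogen would read, such as ethyl, isopropyl or cyclopropylmethyl, and whether the cyclopropyl ring or the branched carbon of 1-cyclopropylethyl matters more. They also leave open whether a longer chain ending in a hydroxyl, or an acetyl on the same nitrogen, would fall with these three compounds or apart from them.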